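Fluorine on the Other Phenyl Ring

This account rests on a few compounds, and the source may have more. Where it says the series, first, only, none or still open, it means among the compounds named here.

In an assay on isolated protein for inhibition of Ephrin type-A receptor 2 (Homo sapiens), read by thermal shift assay, tested at 10 uM (a lower number here means that the compound stabilises the target less, a higher number that the compound stabilises the target more against heat), compound 3 `CC(C)(C)c1cc(NC(=O)Nc2cc(F)cc(F)c2)n(-c2ccccc2)n1` gives 2.7 degrees C, the highest of the three numbers measured. Compound 1 `Cc1ccccc1NC(=O)Nc1cc(C(C)(C)C)nn1-c1ccccc1` gives 1.2 degrees C and compound 2 `Cc1cc(C)cc(NC(=O)Nc2cc(C(C)(C)C)nn2-c2ccccc2)c1` gives 0.7 degrees C; the steps of a number 1.5 degrees C higher from compound 1 to compound 3 (beyond the scatter) and a number 2.0 degrees C higher from compound 2 to compound 3 (beyond the scatter) lie beyond the scatter, while a number 0.50 degrees C lower from compound 1 to compound 2 (within the scatter) does not. Compound 4 `CC(C)(C)c1cc(NC(=O)Nc2cc(F)cc(F)c2)n(-c2ccc(F)cc2)n1` differs from compound 3 by fluoro in place of hydrogen on an aromatic carbon. Going by the values given here, each measured step swaps the aryl group on the amide-type nitrogen; none alters the phenyl ring where this fluorine enters, so no step bears directly on the change. The fluorine added there is expected to leave the number roughly where compound 3 stands, a step of no change at the digits printed from compound 3 to compound 4 (within the scatter). Compound 4 is therefore estimated at 2.7 degrees C, within 1.5 degrees C to 4 degrees C.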

Compound 4, shift of the target's melting temperature: 1.9 degrees C
Compound 4: the middle estimate sits 0.80 degrees C above what was measured; the range from low to high includes it.
By their numbers in this assay, from the lowest: compounds 2, 1, 4 and 3 (each within the scatter of the next, the first and the last beyond it).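

In this assay, the change from phenyl to 4-fluorophenyl gives a number 0.80 degrees C lower from compound 3 to compound 4 (within the scatter), the first step shown on this ring rather than on the aryl group of the amide-type nitrogen. A fluoro on this aromatic carbon, para to a large group, therefore leaves a number that cannot be told apart from the scatter. No measurement on hand speaks to why the step has this size.

On these data alone, whether a larger group at the same place, such as methoxy, an amine or a carboxylic acid, would move the number beyond the scatter stays open.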